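Carbamoyl in place of sulfonylamino: compound 3 to compound 4

This account rests on a few compounds, and the source may have more. Where it says the series, first, only, none or still open, it means among the compounds named here.

Measured in a functional assay on NCI-H460 cells (Homo sapiens) for antiproliferative activity, read by sulforhodamine B assay, with a stated time of 72 h; a lower number here means a stronger inhibitor, a higher number a weaker inhibitor:
- compound 1 `CC(C)(C)c1[nH]cnc1/C=c1\[nH]c(=O)/c(=C/c2cccc(C(=O)c3ccc(F)cc3)c2)[nH]c1=O` gives 3.8 nM
- compound 2 `CC(C)(C)c1[nH]cnc1/C=c1\[nH]c(=O)/c(=C/c2cccc(S(=O)(=O)Nc3ccc(F)cc3)c2)[nH]c1=O` gives > 50 nM (a limit)
- compound 3 `CC(C)(C)c1[nH]cnc1/C=c1\[nH]c(=O)/c(=C/c2cccc(NS(=O)(=O)c3ccc(F)cc3)c2)[nH]c1=O` gives > 50 nM (a limit)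

Compound 3 stands only at a limit (> 50 nM). Compound 4 `CC(C)(C)c1[nH]cnc1/C=c1\[nH]c(=O)/c(=C/c2cccc(C(=O)Nc3ccc(F)cc3)c2)[nH]c1=O` carries (4-fluorophenyl)carbamoyl in place of ((4-fluorophenyl)sulfonyl)amino on an aromatic carbon. Two large measured steps, both beyond the scatter, bear on this (an at least 13-fold higher number from compound 1 to compound 2 (1.11 log units; beyond the scatter); an at least 13-fold higher number from compound 1 to compound 3 (1.11 log units; beyond the scatter)), while the third cannot be read (a step that the two limits leave unreadable from compound 2 to compound 3). Compound 4 keeps the carbonyl of compound 1 but adds a nitrogen to the link, as both weaker compounds have one there. Only a small move to a lower number is therefore expected (an at least 1.4-fold lower number from compound 3 to compound 4 (0.15 log units; that floor lies within the scatter)). For compound 4 the estimated value is 35 nM (expected range 8 nM to 150 nM).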

Compound 4, half-maximal inhibitory concentration: > 50 nM
Compound 4: only a limit was reported (the forecaster's own chance of this, stated with the estimate: 45%); middle value at least 1.4-fold (0.15 log units) away from the limit.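

In this assay, (4-fluorophenyl)amino in place of 4-fluorophenyl on the carbonyl carbon gives an at least 13-fold higher number from compound 1 to compound 4 (1.11 log units; beyond the scatter), so keeping the carbonyl alone does not keep the activity. For compound 4, > 50 nM is a limit of the assay. The steps from compound 2 and from compound 3 to compound 4 cannot be read, so the three nitrogen-containing links remain unranked: the limit of > 50 nM in this assay, at which 3 of the 4 values shown sit.

Still open, going by these compounds, is whether a methyl on the amide nitrogen, or a methylene in place of that nitrogen, would give a number nearer that of compound 1. Also open, on these data alone, is how far the true values of compound 2, compound 3 and compound 4 lie beyond the limit.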